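The compounds below may be only part of what the source reports. "The series", "measured", "known", "first", "only" and "open" are said of these compounds alone.

Measured compounds in a functional assay on the whole organism (integument) for inhibition, with Chilo suppressalis as the target, read by scintillation counting, with a stated time of 72 h; a higher number here means a weaker inhibitor, a lower number a stronger inhibitor:
- compound 1 `COc1cccc(OC)c1C(=O)Nc1nnc(-c2ccc(C(C)C)cc2)s1`: 398 nM
- compound 2 `COc1cccc(OC)c1C(=O)Nc1nnc(-c2ccc(F)cc2)s1`: 97.7 nM
- compound 3 `COc1cccc(OC)c1C(=O)Nc1nnc(-c2ccc(I)cc2)s1`: 89.1 nM

Going by the values given here, compound 3 holds the lowest number of the three in this assay, but its gap to compound 2 is within the scatter, so the two cannot be ordered; only the step from compound 1 stands apart (a 4.5-fold lower number from compound 1 to compound 3 (0.65 log units; beyond the scatter)). The whole set varies at a single aromatic carbon of the shared core.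

Compound 4 `COc1cccc(OC)c1C(=O)Nc1nnc(-c2ccc([N+](=O)[O-])cc2)s1` continues at that same position: nitro in place of iodo on an aromatic carbon. Among the compounds with values here, no measured step involves a nitro group. Within the data shown here, the steps that bear on it are the replacements of the isopropyl group, a 4.1-fold lower number from compound 1 to compound 2 (0.61 log units; beyond the scatter) and a 4.5-fold lower number from compound 1 to compound 3 (0.65 log units; beyond the scatter), both modest and both in the same direction, and the swap between the two halogens, a 1.1-fold lower number from compound 2 to compound 3 (0.04 log units; within the scatter), which is within the scatter. Two different replacements of the isopropyl group gave nearly the same number, so the position seems tolerant, but the data give no basis for expecting a further gain with a nitro group. Compound 4 is therefore expected to stay near compound 3, with the step of a 1.2-fold higher number from compound 3 to compound 4 (0.09 log units; within the scatter) within the scatter. The estimate for compound 4 in this assay is 110 nM, with a range from 45 nM to 270 nM.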

Compound 4, half-maximal inhibitory concentration: 355 nM
Estimate against measurement, compound 4: 3.2-fold (0.51 log units) below; measured number outside the range, above it.
By their numbers in this assay, from the lowest: compounds 3 and 2 (each within the scatter of the next); then compounds 4 and 1 (each within the scatter of the next).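

In this assay, the position proves less forgiving than the first three compounds suggested: nitro in place of iodo gives a 4.0-fold higher number from compound 3 to compound 4 (0.60 log units; beyond the scatter), and nitro in place of fluoro gives a 3.6-fold higher number from compound 2 to compound 4 (0.56 log units; beyond the scatter). Nitro in place of isopropyl gives a 1.1-fold lower number from compound 1 to compound 4 (0.05 log units; within the scatter), so compound 1 and compound 4 cannot be ordered, and the four compounds fall into two levels, with the fluoro and iodo compounds at the lower numbers and the isopropyl and nitro compounds at the higher ones. No measurement available here accounts for this split.

On these data alone, whether the lower level extends to the other halogens remains open, and chloro or bromo at this carbon would test it. An amine or a carboxylic acid at the same place would show whether the higher level holds for other non-halogen groups.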